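Moving the pyridine nitrogen on a near-inactive scaffold

The source may report more compounds than this note shows. Statements on the series, on what has been measured and on what is new or still open speak of the compounds shown alone.

For the measured compounds named here, compound 1 `O=C1OC(c2cccc(Br)c2)=N/C1=C\c1ccncc1` stands highest of the two numbers so far: in an assay on isolated protein for inhibition of Death-associated protein kinase 3 (Homo sapiens), tested at 1 uM (a lower number here means a weaker effect, a higher number a stronger effect of the compound at the concentration tested), compound 1 gives 1%. Compound 2 `O=C1OC(c2cccc([N+](=O)[O-])c2)=N/C1=C\c1ccncc1` gives 0% in this assay, and the step of a number 1 percentage points lower from compound 1 to compound 2 (within the scatter) lies within the scatter. Compound 3 `O=C1OC(c2cccc(Br)c2)=N/C1=C\c1cccnc1` carries the change (pyridin-3-yl in place of pyridin-4-yl on a double-bonded chain carbon bound to a double-bonded ring carbon). Going by the values given here, no measured step bears on this change, and the only step known on the shared core is small, so no movement beyond the scatter is expected; the step of a number 1 percentage points higher from compound 1 to compound 3 (within the scatter) is an estimate only. Compound 3 is expected to give 2% in this assay, within -6% to 12%.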

Compound 3, a percentage reported as inhibition, at one concentration (the size of the read-out at that concentration, not a potency): 100%
Beside the measured number, compound 3's estimate is 98 percentage points below it, and the stated range ends below it.
By their numbers in this assay, from the lowest: compounds 2 and 1 (each within the scatter of the next); then compound 3.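

In this assay, the exchange of pyridin-4-yl for pyridin-3-yl gives a number 99 percentage points higher from compound 1 to compound 3 (beyond the scatter), so the read-out responds strongly at this place, on a double-bonded chain carbon bound to a double-bonded ring carbon. The two groups have the same atoms, joined differently, and that alone separates the compounds. Nothing available explains this step.

Going by these compounds, it remains open whether pyridin-2-yl or plain phenyl at this place would keep the effect. Also open, on these data alone, is whether nitro in place of bromo is tolerated alongside pyridin-3-yl.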